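Swapping one aryl group on a well-tolerated amide

This account rests on a few compounds, and the source may have more. Where it says the series, first, only, none or still open, it means among the compounds named here.

Measured in an ADME assay on HEK293 cells (Homo sapiens) for cytotoxicity, read by reporter gene assay and resazurin assay, with a stated time of 48 h; a higher number here means that more compound is tolerated, a lower number that less compound is tolerated:
Compound 1 `O=C(Nc1ccccc1)c1cc(Br)cc(Br)c1`: > 100000 nM
Compound 2 `COc1ccc(Br)cc1C(=O)Nc1ccc(Sc2nc3ccccc3s2)cc1`: > 100000 nM

Compound 1 gives > 100000 nM, which is a limit of the assay and not a number. Compound 2 stands at > 100000 nM, which is also a limit, so no exact figure is known for it. The next compound to be tested, compound 3 `O=C(Nc1ccc(Sc2nc3ccccc3s2)cc1)c1ccccc1O`, has 2-hydroxyphenyl in place of 5-bromo-2-methoxyphenyl on a carbonyl carbon. Within the data shown here, the two measured compounds do not form a single-change pair, so no measured step guides this expectation. Resting on compound 2 at > 100000 nM, which is a limit, a modest move toward less compound tolerated is expected in this assay. The estimated change is an at least 1.6-fold lower number from compound 2 to compound 3 (0.22 log units; that floor lies within the scatter). The assay may again report only a limit for compound 3. As a number, compound 3 is expected at 60000 nM, with an estimated range of 15000 nM to 100000 nM.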

Compound 3, half-maximal cytotoxic concentration: 74000 nM
Beside the measured number, compound 3's estimate is 1.2-fold (0.09 log units) below it; the measured number falls inside the stated range.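

In this assay, among these compounds, compound 3 is the first of the three compounds to give an exact number and not a limit, which shows that a group on this carbonyl carbon can bring the reading inside the measurable range. Placing 2-hydroxyphenyl in place of 5-bromo-2-methoxyphenyl gives an at least 1.3-fold lower number from compound 2 to compound 3 (0.13 log units; that floor lies within the scatter). That printed figure is only a floor, so the true step could be larger, and its size stays uncertain because the starting value is a limit: the limit of > 100000 nM in this assay, at which 2 of the 3 values shown sit.

The swap removes the bromine and the methoxy group and brings in the hydroxyl group all at once, and the compounds shown do not separate these changes. Also open, going by these compounds, is how a 2-aminophenyl group or a carboxylic acid on this ring would read in this assay.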